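Second chloro on the core of compound 2

The source may hold more compounds than are shown below. What is called first, only, known or untested is meant among the compounds shown, and "the series" means these compounds.

Three purine-type analogues bearing a chloromethyl-substituted benzyl group have been run in a functional assay on KM12 cells (Homo sapiens) for cytotoxicity, read by sulforhodamine B assay, with a stated time of 48 h; on this read-out lower numbers stand for stronger inhibition of growth and higher numbers for weaker inhibition of growth. Compound 1 `ClCc1ccccc1Cn1cnc2c(Cl)ncnc21` gives 33100 nM, compound 2 `ClCc1cccc(Cn2cnc3ncnc(Cl)c32)c1` gives 3310 nM, and compound 3 `ClCc1ccc(Cn2cnc3nc(Cl)nc(Cl)c32)cc1` gives 670 nM. Compound 2 thus stands second highest of the three numbers; compound 3 sits below it, compound 1 well above it, both gaps beyond the usual scatter. Compound 4 `ClCc1cccc(Cn2cnc3nc(Cl)nc(Cl)c32)c1` differs from compound 2 by chloro in place of hydrogen on an aromatic carbon. For the measured compounds named here, no measured pair isolates this change, so the direction rests on compound 3, which carries the same second chloro and gives 670 nM. A moderate step toward stronger growth inhibition is expected, a 3.3-fold lower number from compound 2 to compound 4 (0.52 log units; beyond the scatter). Compound 4 is therefore estimated at 1000 nM, within 300 nM to 4000 nM.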

Compound 4, concentration for total growth inhibition: 35500 nM
Estimate against measurement, compound 4: 36-fold (1.55 log units) below; the whole stated range lies below it.
By their numbers in this assay, from the lowest: compound 3; then compound 2; then compounds 1 and 4 (each within the scatter of the next).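

In this assay, chloro in place of hydrogen between two ring nitrogen atoms weakens growth inhibition in this pair (an 11-fold higher number from compound 2 to compound 4 (1.03 log units; beyond the scatter)), so this position tolerates the change poorly with the chloromethyl group placed as in compound 2. The same second chloro therefore does not bring a low number on its own: compound 3 gives 670 nM and compound 4 gives 35500 nM, with the chloromethyl group sitting differently. Nothing available explains the loss.

Open, going by these compounds, is whether a smaller or different group here, such as fluoro, methyl or an amine, would also weaken growth inhibition. Also open, on these data alone, is how compound 3 would compare with its counterpart lacking the second chloro.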